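Propyl on the terminal alkyne of compound 1

The source may report more compounds than this note shows. Statements on the series, on what has been measured and on what is new or still open speak of the compounds shown alone.

Measured in a functional assay on A2780 cells (Homo sapiens) for inhibition; on this read-out lower numbers stand for stronger inhibition and higher numbers for weaker inhibition:
compound 1 `C#Cc1cc(C)oc(=O)c1`: 3100 nM
compound 2 `CCCCc1cc(C)oc(=O)c1`: > 50000 nM (a limit of the assay, not a number)

Within the data shown here, compound 1 holds the only actual number here, so it can be placed only against the limit of compound 2. The next compound is compound 3 `CCCC#Cc1cc(C)oc(=O)c1`, with the change propyl in place of hydrogen on a triple-bonded carbon. Among the measured compounds shown here, one measured step bears on this, an at least 16-fold higher number from compound 1 to compound 2 (1.20 log units; beyond the scatter), which is large. That step put butyl in place of ethynyl and so lost the triple bond, which compound 3 keeps, making it only a loose guide. A smaller move towards a higher number in this assay is therefore expected. For compound 3 the expected value is 8000 nM, with an estimated range of 1800 nM to 35000 nM. The expected step is a 2.6-fold higher number from compound 1 to compound 3 (0.41 log units; beyond the scatter).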

Compound 3, half-maximal inhibitory concentration: 4800 nM
For compound 3 the middle estimate is 1.7-fold (0.22 log units) above the measured one; measured number inside the range.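

Propyl in place of hydrogen on a triple-bonded carbon gives a 1.5-fold higher number from compound 1 to compound 3 (0.19 log units; within the scatter) in this assay, so compound 1 and compound 3 cannot be ranked, and this position accepts propyl without a change beyond the scatter. The large step, an at least 16-fold higher number from compound 1 to compound 2 (1.20 log units; beyond the scatter), therefore does not carry over to this change, which keeps the triple bond in place. Compound 2, which has no triple bond, stands at a limit of the assay and not at a number: the limit of > 50000 nM in this assay, at which 1 of the 3 values shown sits.

As far as these compounds go, whether a longer chain on the triple-bonded carbon, or an amine at the end of the propyl, would keep the number in this range stays open. From the compounds shown here alone, how much of the step to compound 2 belongs to the triple bond itself also stays open, as that step exchanges the whole ethynyl for butyl.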